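This account rests on a few compounds, and the source may have more. Where it says the series, first, only, none or still open, it means among the compounds named here.

Measured compounds in an assay on isolated protein (strain Sprague-Dawley) for inhibition of Amine oxidase [flavin-containing] B (Rattus norvegicus), read by spectrophotometry, with a stated time of 5 min; a lower number here means a stronger inhibitor, a higher number a weaker inhibitor:

compound 1, `CC(C)Oc1cc(=O)oc2cc(OCc3cccc(Cl)c3)ccc12`: 24500 nM
compound 2, `CN(C)C(=O)COc1cc(=O)oc2cc(OCc3cccc(Cl)c3)ccc12`: 501 nM
compound 3, `O=c1cc(Cl)c2ccc(OCc3cccc(Cl)c3)cc2o1`: 20.9 nM

All three share one core and differ only in the group on a single aromatic carbon. Compound 3, which carries a chloro there, has the lowest number of the three: a 24-fold lower number from compound 2 to compound 3 (1.38 log units; beyond the scatter), and a 1200-fold lower number from compound 1 to compound 3 (3.07 log units; beyond the scatter). Both steps are well beyond the scatter, so compound 3 is the strongest inhibitor among the measured set.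

Compound 4, `O=c1cc(Oc2ccccc2)c2ccc(OCc3cccc(Cl)c3)cc2o1`, differs from compound 3 in one place: phenoxy in place of chloro on an aromatic carbon. Among the compounds with values here, the steps that bear on this change are those at the same carbon, where an oxygen-linked group replaces or is replaced by the chloro. Going from an oxygen-linked group to chloro gave a 1200-fold lower number from compound 1 to compound 3 (3.07 log units; beyond the scatter) and a 24-fold lower number from compound 2 to compound 3 (1.38 log units; beyond the scatter); between the two oxygen-linked groups themselves the difference was a 49-fold lower number from compound 1 to compound 2 (1.69 log units; beyond the scatter). Both measured oxygen-linked groups give higher numbers than the chloro, though by widely different amounts, so the phenoxy is expected to raise the number in this assay, likely by a large step, with its exact size uncertain.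

Compound 4 is therefore estimated at 300 nM in this assay, with an expected range from 40 nM to 3000 nM. This estimate corresponds to an expected 14-fold higher number from compound 3 to compound 4 (1.16 log units; beyond the scatter).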

Compound 4, half-maximal inhibitory concentration: 4070 nM
Beside the measured number, compound 4's estimate is 14-fold (1.13 log units) below it, outside the stated range (above it).
By their numbers in this assay, from the lowest: compound 3; then compound 2; then compound 4; then compound 1.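

In this assay, the phenoxy group of compound 4 lands on the same side of the chloro as the other two oxygen-linked groups, with a 190-fold higher number from compound 3 to compound 4 (2.29 log units; beyond the scatter), so all three oxygen-linked groups shown at this aromatic carbon give higher numbers than the chloro of compound 3. The aromatic ring that enters with the phenoxy does not set it apart from those groups: phenyl on this oxygen falls between the two earlier substituents, with an 8.1-fold higher number from compound 2 to compound 4 (0.91 log units; beyond the scatter) and a 6.0-fold lower number from compound 1 to compound 4 (0.78 log units; beyond the scatter). The group carried on the oxygen therefore moves the number over a wide span, yet every value in that span stays above the value of compound 3, and the largest differences at this carbon remain those between the chloro and the oxygen-linked groups.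

Going by these compounds, whether an amine or a bromo at this carbon would give a number closer to that of compound 3 or of compound 4, and whether a methoxy on the phenyl ring of the phenoxy would shift the number, remains open. Nothing available explains why the chloro stands apart from the oxygen-linked groups or why the phenoxy falls where it does.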